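The source may hold more compounds than are shown below. What is called first, only, known or untested is meant among the compounds shown, and "the series" means these compounds.

In a functional assay on HCT-15 cells (Homo sapiens) for cytotoxicity, read by CCK-8 assay and cell counting, with a stated time of 2 days (on this read-out higher numbers stand for weaker inhibition and lower numbers for stronger inhibition), compound 1 `Oc1ccc(-c2cc(-c3cccs3)nc(-c3ccccc3Cl)c2)cc1` gives 5430 nM, compound 2 `Oc1ccc(-c2cc(-c3ccc(Cl)cc3)nc(-c3cccs3)c2)cc1` gives 6470 nM, and compound 3 `Oc1cccc(-c2cc(-c3cccnc3)nc(-c3ccccc3Cl)c2)c1` gives "not determined" (no result reported).

Compound 2 differs from compound 1 by 4-chlorophenyl in place of 2-chlorophenyl on an aromatic carbon, and in this assay this gave a 1.2-fold higher number from compound 1 to compound 2 (0.08 log units; within the scatter). Compound 4 `Oc1cccc(-c2cc(-c3ccc(Cl)cc3)nc(-c3cccnc3)c2)c1` differs from compound 3 by the same kind of change, (4-chlorophenyl in place of 2-chlorophenyl on an aromatic carbon); around the place, compound 4 carries a 3-hydroxyphenyl group and a pyridin-3-yl group where compound 2 carries a 4-hydroxyphenyl group and a thiophen-2-yl group. How the core of compound 1 differs from the core of compound 3 is not broken down here. Compound 3 has no number. The expectation for compound 4 rests on compound 2 and on the small shift a 1.2-fold higher number from compound 1 to compound 2 (0.08 log units; within the scatter). Compound 4 is therefore estimated at 8000 nM in this assay, expected to fall between 2500 nM and 30000 nM, because compound 2 gives 6470 nM and the change is of the same kind.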

Compound 4, half-maximal inhibitory concentration: 16800 nM
Estimate against measurement, compound 4: 2.1-fold (0.32 log units) below, and the stated range covers the measured number.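

For the compounds shown here, compound 3 has no number to set against compound 4, so no step between them can be read. Whether 4-chlorophenyl in place of 2-chlorophenyl shifts the number in compounds carrying 3-hydroxyphenyl and pyridin-3-yl groups stays open, and no measured property shown bears on this.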